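A few compounds are considered here, and "the series" means these few. Any claim that something is new, unique, unknown or untested is made for them only; others in the source may bear on it.

Measured so far:
- compound 1 `O=c1cc(-c2ccccc2)oc2cc(O)c(OCCCCN3CCCC3)c(O)c12`: in a functional assay on BCG823 cells (Homo sapiens) for antiproliferative activity, read by MTT assay, with a stated time of 48 h (on this read-out higher numbers stand for weaker inhibition and lower numbers for stronger inhibition), compound 1 gives 86400 nM
- compound 2 `CCN(CC)CCCOc1c(OC)cc2oc(-c3ccccc3)cc(=O)c2c1O`: in this assay compound 2 gives 5700 nM

Within the data shown here, of the two numbers, compound 2 holds the lower one; the only neighbour, compound 1, gives a far higher number, and that gap lies beyond the usual scatter. Compound 3 `COc1cc2oc(-c3ccccc3)cc(=O)c2c(O)c1OCCCCN1CCCCC1` is not yet measured. It differs from compound 2 in one place: (piperidin-1-yl)methyl in place of diethylamino on a saturated chain carbon, three bonds along the chain from an oxygen on an aromatic ring. Among the measured compounds shown here, no measured pair shows this change. For compound 3 a step of a 1.1-fold higher number from compound 2 to compound 3 (0.06 log units; within the scatter) is expected, which is small enough to fall within the usual scatter. Compound 3 is therefore estimated at 6500 nM, with a range from 2200 nM to 19000 nM.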

Compound 3, half-maximal inhibitory concentration: 21900 nM
Estimate against measurement, compound 3: 3.4-fold (0.53 log units) below; measured number outside the range, above it.
By their numbers in this assay, from the lowest: compound 2; then compound 3; then compound 1.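

In this assay, this position on the chain is sensitive to the change: a 3.8-fold higher number from compound 2 to compound 3 (0.58 log units; beyond the scatter) is a modest step, but one beyond the scatter, with (piperidin-1-yl)methyl in place of diethylamino. Read one bond further out, the same change is 3-(diethylamino)propyl to 4-(piperidin-1-yl)butyl, so the ring and the added chain length arrive together. No measurement on hand gives a reason for the step.

The compounds shown leave open which of the two goes with the step. A 4-(diethylamino)butyl or a 3-(piperidin-1-yl)propyl group on the same core would separate them.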